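A few compounds are considered here, and "the series" means these few. Any claim that something is new, unique, unknown or untested is made for them only; others in the source may bear on it.

Compound 1 `C=CC(=C)CC[C@@H]1[C@@]2(C)CCC[C@](C)(COC(=O)/C=C/c3ccc(O)cc3)[C@@H]2CC[C@@]1(C)O` was tested in a functional assay on MCF7 cells (Homo sapiens) for cytotoxicity, read by MTT assay, with a stated time of 48 h (a higher number here means a weaker inhibitor, a lower number a stronger inhibitor), where compound 1 gives 16600 nM. Compound 2 `C=C1CC[C@@H]2[C@](C)(CCC[C@]2(C)C(=O)O)[C@H]1C/C=C(\C)C=O` was also tested in this assay; compound 2 gives > 40000 nM, which is a limit of the assay rather than a number, as noted by the limit of > 40000 nM in this assay, at which 1 of the 2 values shown sits. Within the data shown here, compound 1 therefore carries the only definite value shown. Compound 3 `C=CC(=C)CC[C@@H]1[C@@]2(C)CCC[C@](C)(COC(=O)/C=C\c3ccc(O)cc3)[C@@H]2CC[C@@]1(C)O` differs from compound 1 in this way: the two compounds have the same atoms and bonds and differ only in configuration as drawn: 1 of 6 stereo elements differ; a double bond is drawn E in compound 1 and Z in compound 3. Among the measured compounds shown here, no comparable step between measured compounds is available, so the expected change is a 1.2-fold higher number from compound 1 to compound 3 (0.08 log units; within the scatter), a shift not beyond the usual scatter. In this assay compound 3 is estimated at 20000 nM, with a range from 8000 nM to 40000 nM.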

Compound 3, half-maximal inhibitory concentration: 15100 nM
Compound 3: middle estimate off by 1.3-fold (0.12 log units), on the high side, within the range that was stated.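

In this assay, drawing the double bond Z rather than E gives a 1.1-fold lower number from compound 1 to compound 3 (0.04 log units; within the scatter). Among these compounds, this is the first step between measured compounds that differ in one place, and it shows that the geometry of this double bond does not separate the two compounds in this cell test. The comparison isolates that single feature: the fact that compounds 1 and 3 differ only in the configuration as drawn

What the compounds shown leave open is whether other changes matter more. An amine in place of the hydroxyl, or an amide in place of the ester, might shift the number beyond the scatter.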